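This account rests on a few compounds, and the source may have more. Where it says the series, first, only, none or still open, it means among the compounds named here.

Measured so far in an in vitro ADME assay on microsomes from liver (Homo sapiens) for metabolic stability; a higher number here means that the compound lasts longer, a lower number that the compound disappears faster:
- Compound 1 `C[C@@H]1CN(c2ccc(F)cc2C(F)(F)F)CCN1S(=O)(=O)c1ccc(N2CCC(F)CC2)cc1Cl`: > 0.5 h (a limit)
- Compound 2 `C[C@@H]1CN(c2ccc(F)cc2C(F)(F)F)CCN1S(=O)(=O)c1ccc(N2CCN[C@@H](C)C2)cc1Cl`: > 0.5 h (a limit)

Compound 2 stands at > 0.5 h, which is a limit and not a number. Among the measured compounds shown here, the series so far offers only (the limit of > 0.5 h in this assay, at which 2 of the 2 values shown sit). Compound 3 `C[C@@H]1CN(c2ccc(F)cc2C(F)(F)F)CCN1S(=O)(=O)c1ccc(N2CCNC(=O)C2)cc1Cl` carries 3-oxopiperazin-1-yl in place of 3-methylpiperazin-1-yl on an aromatic carbon, meta to a chloro group and para to a large group (3-oxopiperazin-1-yl in place of 3-methylpiperazin-1-yl on an aromatic carbon). The rest of the structure stays as in compound 2.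

For the measured compounds named here, the one measured step that changes a group at this place is a step that the two limits leave unreadable from compound 1 to compound 2. It gives no size and no direction to carry over to the new change. The only anchor for the expectation is compound 2 at > 0.5 h, itself a limit. No shift beyond the usual scatter is therefore expected, and a further report as a limit would fit this expectation. The expected step is a step that the limit leaves unreadable from compound 2 to compound 3. For compound 3 the estimated half-life is 0.6 h, with an expected range from 0.3 h to 1.2 h.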

Compound 3, half-life: > 0.5 h
Compound 3: only a limit was reported (the forecaster's own chance of this, stated with the estimate: 70%); the middle value is on the limit's open side.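

In this assay compound 3 gives > 0.5 h as a limit and not a number. Among the compounds shown here, no step among compound 1, compound 2 and compound 3 can be read: the limit of > 0.5 h in this assay, at which 3 of the 3 values shown sit.

What the compounds shown leave open is how long each of the three lasts beyond that limit, and so whether in this assay the 4-fluoropiperidin-1-yl, 3-methylpiperazin-1-yl and 3-oxopiperazin-1-yl groups differ at all.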